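From (4-Chlorobenzyl)sulfanyl to Hydroxy(4-methoxyphenyl)methyl

The source may hold more compounds than are shown below. What is called first, only, known or untested is meant among the compounds shown, and "the series" means these compounds.

Measured in a functional assay on RAW264.7 cells (Mus musculus) for inhibition, with stated times of 2 h and 24 h; a lower number here means a stronger inhibitor, a higher number a weaker inhibitor:
- Compound 1 `COc1ccc(CSC2c3cc(OC)cc(OC)c3[C@@H](c3ccc(OC)cc3)[C@@H]2c2cc(OC)cc(OC)c2)cc1`: 12500 nM
- Compound 2 `COc1ccc([C@@H]2c3c(OC)cc(OC)cc3C(SCc3ccc(C)cc3)[C@H]2c2cc(OC)cc(OC)c2)cc1`: > 200000 nM (a limit)
- Compound 3 `COc1ccc([C@@H]2c3c(OC)cc(OC)cc3C(SCc3ccc(Cl)cc3)[C@H]2c2cc(OC)cc(OC)c2)cc1`: > 200000 nM (a limit)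

Compound 3 stands at > 200000 nM, which is a limit and not a number. Compound 4 `COc1ccc(C(O)C2c3cc(OC)cc(OC)c3[C@@H](c3ccc(OC)cc3)[C@@H]2c2cc(OC)cc(OC)c2)cc1` is not yet measured. It differs from compound 3 as follows: hydroxy(4-methoxyphenyl)methyl in place of (4-chlorobenzyl)sulfanyl on a saturated ring carbon. Within the data shown here, two measured steps bear on this change, both large and beyond the scatter: an at least 16-fold higher number from compound 1 to compound 2 (1.20 log units; beyond the scatter) and an at least 16-fold higher number from compound 1 to compound 3 (1.20 log units; beyond the scatter). In both, methoxy on an aromatic carbon is replaced. The entering group of compound 4 carries a methoxy again, and compound 1 at 12500 nM holds one too, so a step to a lower number is expected in this assay. Among the measured compounds shown here, no measured step covers the hydroxy group or the loss of the sulfur, so the size remains uncertain. The expected step is an at least 5.0-fold lower number from compound 3 to compound 4 (0.69 log units; beyond the scatter). For compound 4 the estimate is 40000 nM, with an expected range of 8000 nM to 200000 nM.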

Compound 4, half-maximal inhibitory concentration: > 200000 nM
Compound 4 gave a limit, no number; the forecaster's own chance of this, stated with the estimate: 35%; middle value at least 5.0-fold (0.69 log units) from the limit.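

In this assay, hydroxy(4-methoxyphenyl)methyl in place of (4-methoxybenzyl)sulfanyl on the saturated ring carbon gives an at least 16-fold higher number from compound 1 to compound 4 (1.20 log units; beyond the scatter), a step read against a limit. The earlier compounds shown here showed only that replacing the methoxy on the benzyl ring is not tolerated; compound 4 shows that a methoxy on the entering aromatic ring does not by itself retain the number of compound 1, so the change at this ring carbon also matters. The steps to compound 4 from compound 2 and from compound 3 cannot be read, and compound 1 remains the only compound with a number: the limit of > 200000 nM in this assay, at which 3 of the 4 values shown sit.

From the compounds shown here alone, compound 4 changes the sulfur and adds the hydroxy in one move, so the share of each remains open. Also open, going by these compounds, is whether an amine in place of the hydroxy, or a longer chain to the aromatic ring, would give a number below the limit.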